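This account rests on a few compounds, and the source may have more. Where it says the series, first, only, none or still open, it means among the compounds named here.

Measured compounds:
- compound 2, `FC(F)c1ccccc1-c1nc(NCc2ccc(-c3cccnc3)cc2)c2ccccc2n1`: 1400 nM
- compound 1, `FC(F)(F)c1cccc(-c2nc(NCc3ccc(-c4cccnc4)cc3)c3ccccc3n2)c1`: "not active" (no number reported)

Within the data shown here, compound 2 is the only compound of the pair with a number in an assay on a protein complex for inhibition of ubiquitin carboxyl-terminal hydrolase 1/WD repeat-containing protein 48 (Homo sapiens), read by fluorescence (a higher number here means a weaker inhibitor, a lower number a stronger inhibitor), where compound 2 gives 1400 nM. Compound 1 is recorded in this assay as "not active" (no number reported), with no number behind it, so compound 2 stands alone as the reference point; nothing can be said about how far apart the two compounds lie.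

Compound 3, `c1cncc(-c2ccc(CNc3nc(N4CCCC4)nc4ccccc34)cc2)c1`, is not yet measured. It differs from compound 2 by pyrrolidin-1-yl in place of 2-(difluoromethyl)phenyl on an aromatic carbon; the group that leaves is an aromatic ring, the group that enters a five-membered non-aromatic ring with one hetero atom, seated on the aromatic carbon between two ring nitrogen atoms of the shared core.

Among the measured compounds shown here, no step between measured compounds is available to calibrate such a change. For the measured compounds named here, with one number only, the expectation is a step well beyond the scatter in this assay, and compound 3 is expected to come out weaker than compound 2, since the only numbered compound carries the aromatic group; the estimated step is a 4.3-fold higher number from compound 2 to compound 3 (0.63 log units; beyond the scatter). For compound 3 the estimate in this assay is 6000 nM, in the range 900 nM to 40000 nM, with a real chance that only a limit is returned.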

Compound 3, half-maximal inhibitory concentration: "not active" (no number reported)
Nothing numeric was reported for compound 3; the estimate stays without a comparison.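

In this assay compound 3 gives "not active" (no number reported) and so, like compound 1, offers no number to set against compound 2; no new step can be read. No evidence bears on this result. The compounds shown leave open how far compound 1 and compound 3 lie from compound 2, and whether any other group in place of 2-(difluoromethyl)phenyl gives a number.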